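The compounds below may be only part of what the source reports. "The series", "measured", "known", "first", "only" and "open" are said of these compounds alone.

Compound 1 `C=CCOc1ccc(C(=O)Nc2cccc(C)n2)cc1` gives 6000 nM in an in vitro assay on HEK-tsA201 cells for antagonist activity at Neuronal acetylcholine receptor; alpha4/beta2 (Homo sapiens), read by fluorescence and calcium flux (a lower number here means a stronger inhibitor, a higher number a weaker inhibitor), the lowest of the three numbers in hand. Compound 3 `CCCOc1ccc(C(=O)Nc2cccc(C)n2)cc1` gives 7500 nM there, and the step of a 1.3-fold higher number from compound 1 to compound 3 (0.10 log units; within the scatter) stays within the scatter. Compound 2 `C#CCOc1ccc(C(=O)Nc2cccc(C)n2)cc1` gives 19400 nM; the step of a 3.2-fold higher number from compound 1 to compound 2 (0.51 log units; beyond the scatter) is the only one of appreciable size, and the step of a 2.6-fold lower number from compound 2 to compound 3 (0.41 log units; beyond the scatter) covers the same ground from the other side. All three measured steps concern the saturated chain carbon bound to an oxygen on the aromatic ring and leave the shared core untouched.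

Compound 4 `C=CCOc1ccc(C(=O)Nc2cccc(Cl)n2)cc1` differs from compound 1 on the core instead: chloro in place of methyl on an aromatic carbon. Within the data shown here, no measured step in this assay touches the core, so the three steps in hand, all on the chain, give no guide to the size or direction of the swap of methyl for chloro. Among the measured compounds shown here, with no bearing step, the expected step is no change at the digits printed from compound 1 to compound 4 (within the scatter), taken as within the scatter, with a wide allowance either way. Compound 4 is therefore estimated at 6000 nM in this assay, within a range of 2000 nM to 20000 nM, pending the measurement.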

Compound 4, half-maximal inhibitory concentration: > 100000 nM
Compound 4 was reported as a limit (the forecaster's own chance of this, stated with the estimate: 10%); middle value at least 16-fold (1.22 log units) away from the limit.
By their numbers in this assay, from the lowest: compounds 1 and 3 (each within the scatter of the next); then compound 2. At a limit, above all of these: compound 4.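

Among these compounds, the step of an at least 16-fold higher number from compound 1 to compound 4 (1.22 log units; beyond the scatter) is the first one on the shared core, and it is rated large, whereas the largest chain step, a 3.2-fold higher number from compound 1 to compound 2 (0.51 log units; beyond the scatter), is rated modest. In this assay compound 4 reads > 100000 nM, which is a limit of the assay and not a number: the limit of > 100000 nM in this assay, at which 1 of the 4 values shown sits. This position, on an aromatic carbon next to the ring nitrogen, therefore tolerates far less change than the chain does in this one pair, even though the swap of methyl for chloro leaves the heavy-atom count unchanged and brings in no hydrogen-bond donor or acceptor and no net charge, so these counts give no account of the loss.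

The compounds shown leave open whether the loss is peculiar to chloro or extends to other replacements of methyl here, such as a hydrogen, an ethyl, a methoxy or a trifluoromethyl group. They also leave open how far the loss runs past the limit, and whether the same swap does the same on the chains of compound 2 and compound 3.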